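The compounds below may be only part of what the source reports. "The series", "measured", "known", "first", "only" and "open" are said of these compounds alone.

Compound 1 `Cc1c(-c2cncc(-c3ccc(OC(F)(F)F)cc3)c2)[nH]c2ccccc2c1=O` shares its core with two close relatives. In a physicochemical assay for solubility, measured as kinetic solubility, at pH 7.4, tested at 200 uM (on this read-out higher numbers stand for higher solubility and lower numbers for lower solubility), compound 1 gives 3600 nM. Compound 2 `COc1ccc2c(=O)c(C)c(-c3ccnc(-c4ccc(OC(F)(F)F)cc4)c3)[nH]c2c1` reaches only a limit of this assay, < 1000 nM. Compound 3 `COc1ccc2c(=O)c(C)c(-c3cncc(-c4ccc(OC(F)(F)F)cc4)c3)[nH]c2c1` likewise gives only a limit, < 1000 nM. How the cores of compound 2 and compound 3 differ is not broken down here. The change from compound 3 to compound 1 is hydrogen in place of methoxy on an aromatic carbon, and it produced an at least 3.6-fold higher number from compound 3 to compound 1 (0.55 log units; beyond the scatter), a step whose size is set by the limit of < 1000 nM in this assay, at which 2 of the 3 values shown sit. Compound 4 `Cc1c(-c2ccnc(-c3ccc(OC(F)(F)F)cc3)c2)[nH]c2ccccc2c1=O` has not yet been measured in this assay; it differs from compound 2 by the same change, (hydrogen in place of methoxy on an aromatic carbon). Resting on the step of an at least 3.6-fold higher number from compound 3 to compound 1 (0.55 log units; beyond the scatter), a step of an at least 2.5-fold higher number from compound 2 to compound 4 (0.39 log units; beyond the scatter) is expected. Compound 4 is therefore estimated at 2500 nM in this assay.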

Compound 4, solubility: 2100 nM
Compound 4: the middle estimate sits 1.2-fold (0.08 log units) above what was measured; measured number inside the range.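

Hydrogen in place of methoxy on an aromatic carbon gives an at least 2.1-fold higher number from compound 2 to compound 4 (0.32 log units; beyond the scatter) in this assay, the same direction as an at least 3.6-fold higher number from compound 3 to compound 1 (0.55 log units; beyond the scatter), so the direction of the change carried over from the core of compound 1 to the core of compound 4. This rests on only these two pairs and shows nothing about any other core. Each step is only a lower bound, and the two sizes cannot be compared, because both start from a limit rather than a number: the limit of < 1000 nM in this assay, at which 2 of the 4 values shown sit.

The compounds shown carry only hydrogen or methoxy at this place. From the compounds shown here alone, how an amine, a carboxylic acid or a longer chain such as butoxy would read there remains open.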